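From compound 3 to compound 4: one aryl group exchanged

The source may hold more compounds than are shown below. What is called first, only, known or untested is meant among the compounds shown, and "the series" means these compounds.

In an ADME assay on MT4 cells (Homo sapiens) for cytotoxicity, read by MTT assay (a lower number here means that less compound is tolerated, a higher number that more compound is tolerated), compound 3 (`Cc1ccc(N(C(=O)c2ccc([N+](=O)[O-])cc2Cl)C(=S)OCCN2C(=O)c3ccccc3C2=O)cc1`) gives 17000 nM and lies within the scatter of compound 2 (`Cc1ccc(N(C(=O)c2c(Cl)cccc2Cl)C(=S)OCCN2C(=O)c3ccccc3C2=O)cc1`) at 22000 nM on this read-out. Compound 1 (`O=C1c2ccccc2C(=O)N1CCOC(=S)N(C(=O)c1ccc(Cl)c([N+](=O)[O-])c1)c1ccccc1`) reads 51000 nM and stands higher than compound 3, beyond the scatter. Compound 4 (`Cc1ccc(N(C(=O)c2ccc(Cl)c([N+](=O)[O-])c2)C(=S)OCCN2C(=O)c3ccccc3C2=O)cc1`) has the same atoms as compound 3, joined differently (4-chloro-3-nitrophenyl in place of 2-chloro-4-nitrophenyl on a carbonyl carbon) so that 4-chloro-3-nitrophenyl takes the place of 2-chloro-4-nitrophenyl on a carbonyl carbon. Among the compounds with values here, the only measured step at this place is a 1.3-fold lower number from compound 2 to compound 3 (0.11 log units; within the scatter) and it stays within the scatter. Compound 1 also carries 4-chloro-3-nitrophenyl, and its number of 51000 nM gives a slight upward lean, although the two compounds are not a direct pair. A small rise is therefore expected, estimated as a 1.5-fold higher number from compound 3 to compound 4 (0.17 log units; within the scatter) and not beyond the scatter. For compound 4 the estimated value is 25000 nM with an expected range of 10000 nM to 60000 nM around it.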

Compound 4, half-maximal cytotoxic concentration: 47000 nM
Compound 4: the middle estimate sits 1.9-fold (0.27 log units) below what was measured, and the stated range covers the measured number.
By their numbers in this assay, from the lowest: compounds 3 and 2 (each within the scatter of the next); then compounds 4 and 1 (each within the scatter of the next).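

In this assay the exchange of 2-chloro-4-nitrophenyl for 4-chloro-3-nitrophenyl on a carbonyl carbon gives a 2.8-fold higher number from compound 3 to compound 4 (0.44 log units; beyond the scatter) and shows that rearranging the same atoms within this aryl group can produce a step beyond the scatter, which the earlier step at this place did not. 4-chloro-3-nitrophenyl in place of 2,6-dichlorophenyl also gives a step beyond the scatter, a 2.1-fold higher number from compound 2 to compound 4 (0.33 log units; beyond the scatter) while methyl in place of hydrogen on an aromatic carbon gives a 1.1-fold lower number from compound 1 to compound 4 (0.04 log units; within the scatter) and stays within it. Nothing measured here accounts for these steps.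

The compounds shown do not separate the part played by the chlorine from that of the nitro group. On these data alone, whether an aryl group carrying an amine or a carboxylic acid would read with compound 3 or with compound 4 also remains open.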